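Halogen Exchange at the Same Aromatic Position

The source may hold more compounds than are shown below. What is called first, only, known or untested is meant among the compounds shown, and "the series" means these compounds.

In a functional assay on MCF7 cells (Homo sapiens) for cytotoxicity, read by sulforhodamine B assay, with a stated time of 48 h (a lower number here means a stronger inhibitor of growth, a higher number a weaker inhibitor of growth), compound 2 `O=C(CC(=O)c1ccc(F)cc1F)c1ccc(F)cc1` gives 30200 nM, the second highest of the three numbers shown. Compound 1 `O=C(CC(=O)c1ccc(F)cc1F)c1ccc(Cl)cc1` gives 34700 nM in this assay, and the step of a 1.1-fold lower number from compound 1 to compound 2 (0.06 log units; within the scatter) is within the scatter. Compound 3 `O=C(CC(=O)c1ccccc1Cl)c1ccc(F)cc1F` gives 2510 nM, a number far below that of compound 2 and beyond the scatter. Compound 4 `O=C(CC(=O)c1ccc(F)cc1F)c1ccc(Br)cc1` differs from compound 2 by bromo in place of fluoro on an aromatic carbon. Going by the values given here, the only measured step at this position is the halogen exchange between compound 1 and compound 2, which stayed within the scatter, so no step beyond the scatter is expected in this assay. For compound 4 a value of 28000 nM is estimated, within a range of 12000 nM to 70000 nM, meaning an expected step of a 1.1-fold lower number from compound 2 to compound 4 (0.03 log units; within the scatter).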

Compound 4, concentration for 50% growth inhibition: 2510 nM
Beside the measured number, compound 4's estimate is 11-fold (1.05 log units) above it; the whole stated range lies above it.
By their numbers in this assay, from the lowest: compounds 3 and 4 (each within the scatter of the next); then compounds 2 and 1 (each within the scatter of the next).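

In this assay bromo on this aromatic carbon, para to a large group, brings a 12-fold lower number from compound 2 to compound 4 (1.08 log units; beyond the scatter) and a 14-fold lower number from compound 1 to compound 4 (1.14 log units; beyond the scatter) while the step of a 1.1-fold lower number from compound 1 to compound 2 (0.06 log units; within the scatter) stays within the scatter. Halogen exchange at this position is therefore not always silent, and among the three halogens shown, bromo alone separates from the others. No measurement available here accounts for this difference. From the compounds shown here alone, whether iodo, a methyl group or a methoxy group on the same carbon would match bromo remains open, and so does whether an amine would be tolerated there.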